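The source may report more compounds than this note shows. Statements on the series, on what has been measured and on what is new or still open speak of the compounds shown alone.

Compound 2 `COC(=O)c1sc2cc(-c3cccs3)cnc2c1N` sits at a limit of a functional assay on A-375 cells (Homo sapiens) for inhibition, read by sulforhodamine B assay, with a stated time of 48 h; on this read-out higher numbers stand for weaker inhibition of growth and lower numbers for stronger inhibition of growth: in this assay compound 2 gives > 150000 nM, a limit rather than a number. Among the measured compounds it is joined there by compound 3 `COC(=O)c1sc2cc(-c3ccc(-c4cccs4)s3)cnc2c1N`, for which this assay gives > 75000 nM, also a limit. Compound 1 `COC(=O)c1sc2cc(-c3ccsc3)cnc2c1N` gives 12100 nM in this assay. The change to compound 4 `COC(=O)c1sc2cc(-c3ccoc3)cnc2c1N` is furan-3-yl in place of thiophen-2-yl on an aromatic carbon. The step that bears on it runs the other way, an at least 12-fold higher number from compound 1 to compound 2 (1.09 log units; beyond the scatter), whereas a step that the two limits leave unreadable from compound 2 to compound 3 says nothing readable. Since compound 4 carries a 3-linked ring as compound 1 does, with 12100 nM, a large step back towards stronger inhibition is expected, an at least 7.5-fold lower number from compound 2 to compound 4 (0.87 log units; beyond the scatter). Compound 4 is therefore estimated at 20000 nM, between 6000 nM and 80000 nM.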

Compound 4, concentration for 50% growth inhibition: > 120000 nM
Compound 4: no number, only a limit; the forecaster's own chance of this, stated with the estimate: 20%; at least 6.0-fold (0.77 log units) between middle value and limit.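

In this assay compound 4 gives only a limit, not a number: the limit of > 120000 nM in this assay, at which 1 of the 4 values shown sits. Replacing thiophen-3-yl with furan-3-yl at this position gives an at least 9.9-fold higher number from compound 1 to compound 4 (0.99 log units; beyond the scatter), so the thiophen-3-yl of compound 1 is not matched by furan-3-yl, and compound 1 alone among the compounds shown gives a number. The steps between compounds that both stand at limits cannot be read.

From the compounds shown here alone, whether a phenyl ring or an aminomethyl group at this position would give a number in this assay stays open. So does how far compound 2 and compound 4 lie beyond their limits.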